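Pyrrolidine in Place of Diethylamine in a Cytotoxicity Series

A few compounds are considered here, and "the series" means these few. Any claim that something is new, unique, unknown or untested is made for them only; others in the source may bear on it.

The measured compounds, all in a functional assay on U-937 cells (Homo sapiens) for cytotoxicity, read by WST assay, with a stated time of 72 h; on this read-out lower numbers stand for stronger inhibition and higher numbers for weaker inhibition:
Compound 1, `CCN(CC)CCCOc1cc2ncnc(Nc3nc4ccc(C(=O)Nc5c(C)cccc5C)cc4s3)c2cc1OC`, gives 23700 nM.
Compound 2, `CCN(CC)CCCOc1cc2ncnc(Nc3nc4ccc(C(=O)Nc5c(C)cccc5Cl)cc4s3)c2cc1OC`, gives 7300 nM.
Compound 3, `COc1cc2c(Nc3nc4ccc(C(=O)Nc5c(C)cccc5C)cc4s3)ncnc2cc1OCCCN1CCC(C)CC1`, gives 11200 nM.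

Compound 2 gives the lowest of the three numbers in this assay, though its gap to compound 3 lies within the scatter; only compound 1 sits clearly apart, the step of a 3.2-fold lower number from compound 1 to compound 2 (0.51 log units; beyond the scatter) being beyond the scatter.

Compound 4, `COc1cc2c(Nc3nc4ccc(C(=O)Nc5c(C)cccc5Cl)cc4s3)ncnc2cc1OCCCN1CCCC1`, is not yet measured. It differs from compound 2 as follows: pyrrolidin-1-yl in place of diethylamino on a saturated chain carbon, three bonds along the chain from an oxygen on an aromatic ring. Going by the values given here, one measured step bears on this change: a 2.1-fold lower number from compound 1 to compound 3 (0.33 log units; beyond the scatter), where a cyclic amine also took the place of diethylamino at the same chain position. That step was modest, and pyrrolidin-1-yl is a smaller ring than 4-methylpiperidin-1-yl, so a comparable or smaller effect is expected in this assay, in the direction of a lower number, possibly not beyond the scatter.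

Compound 4 is therefore expected to give about 5000 nM in this assay, within a range of 2000 nM to 12000 nM. The estimated step of a 1.5-fold lower number from compound 2 to compound 4 (0.16 log units; within the scatter) is expected to be small.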

Compound 4, half-maximal inhibitory concentration: 19900 nM
Beside the measured number, compound 4's estimate is 4.0-fold (0.60 log units) below it; the measured number lies above the stated range.
By their numbers in this assay, from the lowest: compounds 2, 3, 4 and 1 (each within the scatter of the next, the first and the last beyond it).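

In this assay, putting a cyclic amine in place of diethylamino at this chain position does not move the number in one direction: pyrrolidin-1-yl gives a 2.7-fold higher number from compound 2 to compound 4 (0.44 log units; beyond the scatter) and thus runs opposite to 4-methylpiperidin-1-yl, which gave a 2.1-fold lower number from compound 1 to compound 3 (0.33 log units; beyond the scatter) on its own background. Diethylamino and pyrrolidin-1-yl have the same count of heavy atoms and the same hydrogen-bond acceptor count, so this position responds even to a change that adds no heavy atom and only ties the amine into a five-membered ring. No supporting data are available to explain this shift.

From the compounds shown here alone, the two amine steps start from compounds that differ by chloro in place of methyl on an aromatic carbon, so it remains open whether their opposite directions follow from the two amines or from that aromatic difference. Also open, going by these compounds, is how other amines on this chain, such as morpholin-4-yl or dimethylamino, would behave, and whether a shorter 2-(pyrrolidin-1-yl)ethyl chain would give a different number from the 3-(pyrrolidin-1-yl)propyl chain.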